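A few compounds are considered here, and "the series" means these few. Any claim that something is new, unique, unknown or untested is made for them only; others in the source may bear on it.

In a functional assay for inhibition, with Homo sapiens as the target (a higher number here means a weaker inhibitor, a lower number a stronger inhibitor), compound 1 `COc1cccc(Nc2nccc(-c3ccncc3)n2)c1` gives 400 nM, and compound 2 `c1cc(Nc2nccc(-c3ccncc3)n2)cc(OCCn2ccnc2)c1` gives 200 nM. These two numbers cannot really be told apart: the measured step is a 2.0-fold lower number from compound 1 to compound 2 (0.30 log units; within the scatter), so compound 2 has no firm lead over compound 1.

Compound 3 `c1cc(Nc2nccc(-c3cccnc3)n2)cc(OCCn2ccnc2)c1` is compound 2 with one group altered, pyridin-3-yl in place of pyridin-4-yl on an aromatic carbon. The same atoms are simply joined differently.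

For the measured compounds named here, the one measured step concerns a change at another place in the molecule, and no measured pair tests this swap. It therefore gives neither a size nor a direction for the new step, and no step beyond the scatter is expected in this assay. The expected change is a 1.3-fold higher number from compound 2 to compound 3 (0.10 log units; within the scatter). For compound 3 the estimated value is 250 nM, with an expected range from 70 nM to 900 nM.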

Compound 3, half-maximal inhibitory concentration: 100 nM
The estimate for compound 3 lay 2.5-fold (0.40 log units) above the measured number; low and high end bracket the measured number.
By their numbers in this assay, from the lowest: compounds 3, 2 and 1 (each within the scatter of the next, the first and the last beyond it).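

In this assay, for the compounds shown here, putting pyridin-3-yl in place of pyridin-4-yl gives a 2.0-fold lower number from compound 2 to compound 3 (0.30 log units; within the scatter), the first measured change at this aromatic carbon. The pyridine ring can therefore be joined through a different ring carbon, with the same atoms in the molecule, without a step that stands out from the scatter. Nothing available explains this result or says how the two pyridine forms differ in their action.

Going by these compounds, both compounds with a change at this position still carry a pyridine ring there, so it remains open whether pyridin-2-yl or a plain phenyl ring would give a similar number. A single swap also cannot show whether a larger change here, such as a pyridine ring bearing an amine, would produce a step beyond the scatter.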